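Benzyl to aryl swap and passive permeability

A few compounds are considered here, and "the series" means these few. Any claim that something is new, unique, unknown or untested is made for them only; others in the source may bear on it.

Measured compounds:
compound 1, `COc1cccc(CNCCCNc2ccnc3cc(Cc4ccccc4)ccc23)c1O`: 23 10^-6 cm/s
compound 2, `COc1cccc(CNCCCNc2ccnc3cc(-c4ccc(F)cc4)ccc23)c1O`: 237 10^-6 cm/s
compound 3, `COc1cccc(CNCCCNc2ccnc3cc(Cc4ccc(F)cc4Cl)ccc23)c1O`: 23 10^-6 cm/s

In an ADME assay for permeability, using PAMPA, with a stated time of 30 min, at pH 7.4 (on this read-out higher numbers stand for higher permeability and lower numbers for lower permeability), compound 3 stands together with compound 1 at the lowest of the three numbers; between them there is no change at the digits printed from compound 1 to compound 3 (within the scatter). Compound 2 sits well apart, with a 10-fold lower number from compound 2 to compound 3 (1.01 log units; beyond the scatter) on the way down to compound 3.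

Compound 4, `COc1ccc(-c2ccc3c(NCCCNCc4cccc(OC)c4O)ccnc3c2)cc1`, has not yet been measured in this assay. Against compound 3 the change is 4-methoxyphenyl in place of 2-chloro-4-fluorobenzyl on an aromatic carbon.

Within the data shown here, two measured steps bear on this. Both involve exchanging a benzyl group on the core for a phenyl ring placed directly on the aromatic carbon: a 10-fold higher number from compound 1 to compound 2 (1.01 log units; beyond the scatter), and in the opposite sense a 10-fold lower number from compound 2 to compound 3 (1.01 log units; beyond the scatter). Compound 4 carries 4-methoxyphenyl at the same place where compound 2 carries 4-fluorophenyl, so the step from compound 3 is of the same kind as the step from compound 1 to compound 2. Among the measured compounds shown here, no measured pair shows how 4-methoxyphenyl compares with 4-fluorophenyl, so that part of the change adds uncertainty.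

A large rise is therefore expected for compound 4, roughly a 6.5-fold higher number from compound 3 to compound 4 (0.81 log units; beyond the scatter). Compound 4 is estimated at 150 10^-6 cm/s, with a range from 60 10^-6 cm/s to 400 10^-6 cm/s.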

Compound 4, apparent permeability in the ADME assay: 237 10^-6 cm/s
Estimate against measurement, compound 4: 1.6-fold (0.20 log units) below, and the stated range covers the measured number.
By their numbers in the ADME assay, from the lowest: compounds 1 and 3 (each within the scatter of the next); then compounds 2 and 4 (each within the scatter of the next).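

Among these compounds, in the ADME assay, 4-methoxyphenyl in place of 4-fluorophenyl gives no change at the digits printed from compound 2 to compound 4 (within the scatter), so the first comparison of two different groups on a ring attached directly at this position shows no separation. Against the benzyl-type groups, the new compound repeats the large gap seen for compound 2, with a 10-fold higher number from compound 1 to compound 4 (1.01 log units; beyond the scatter) and a 10-fold higher number from compound 3 to compound 4 (1.01 log units; beyond the scatter); across these four compounds, both directly attached rings stand apart from both benzyl groups, and none goes against this split. In a physicochemical assay for acid dissociation, compound 3 gives 9.47 and compound 4 gives 9.47, which is no change at the digits printed from compound 3 to compound 4 (within the scatter), so the same pair that shows a large step in the ADME assay shows none on this read-out.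

No measurement shown gives a reason for the gap between the two kinds of group. The compounds shown leave open how 2-chloro-4-fluorophenyl attached directly at this position would compare with 2-chloro-4-fluorobenzyl, and whether a directly attached phenyl ring carrying an amine or a carboxylic acid would stand with compounds 2 and 4.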